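A Fluorine Added Beside the Methylsulfonyl Anchor

The compounds below may be only part of what the source reports. "The series", "measured", "known", "first", "only" and "open" are said of these compounds alone.

Three compounds share one core, a piperidine amide carrying a cyclopropyl sulfonamide. Compound 1 `CS(=O)(=O)c1ccc(C(=O)N2CCC(N(C3CC3)S(=O)(=O)c3cccc(C(F)(F)F)c3)CC2)cc1` has "not determined" (no result reported) in an assay on cells for inhibition of Voltage-dependent L-type calcium channel subunit alpha-1C (Homo sapiens), read by FLIPR and calcium flux, tested at 3 uM; on this read-out higher numbers stand for a stronger effect at the one concentration tested and lower numbers for a weaker effect. For the measured compounds named here, compound 2 `NC(=O)c1ccccc1C(=O)N1CCC(N(C2CC2)S(=O)(=O)c2cccc(C(F)(F)F)c2)CC1` gives 17% in this assay, and compound 3 `CS(=O)(=O)c1ccccc1C(=O)N1CCC(N(C2CC2)S(=O)(=O)c2cccc(C(F)(F)F)c2)CC1` gives 39%, the higher of the two numbers reported, with the only measured step being a number 22 percentage points higher from compound 2 to compound 3 (beyond the scatter).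

Compound 4 `CS(=O)(=O)c1ccc(F)cc1C(=O)N1CCC(N(C2CC2)S(=O)(=O)c2cccc(C(F)(F)F)c2)CC1` differs from compound 3 by fluoro in place of hydrogen on an aromatic carbon, placed on an aromatic carbon of a six-membered aromatic ring of carbon only, para to a methylsulfonyl group. Going by the values given here, no measured step concerns this kind of change: the one step available swaps a whole group on the ring rather than adding a single fluorine, so it bears on the question only by showing the ring tolerates substitution changes. With so small an addition, compound 4 is expected to remain close to compound 3, an expected step of a number 3 percentage points higher from compound 3 to compound 4 (within the scatter), not beyond the scatter. For compound 4 the estimate in this assay is 42%, ranging from 22% to 62%.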

Compound 4, a percentage reported as inhibition, at one concentration (the size of the read-out at that concentration, not a potency): 34%
For compound 4 the middle estimate is 8 percentage points above the measured one; low and high end bracket the measured number.
By their numbers in this assay, from the lowest: compound 2; then compounds 4 and 3 (each within the scatter of the next).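

In this assay, fluoro in place of hydrogen on an aromatic carbon para to a methylsulfonyl group gives a number 5 percentage points lower from compound 3 to compound 4 (within the scatter) and so leaves no change at this position that can be told from the scatter. The 5-fluoro-2-(methylsulfonyl)phenyl group in place of 2-carbamoylphenyl gives a number 17 percentage points higher from compound 2 to compound 4 (beyond the scatter) and so the difference from the carbamoyl compound, seen earlier as a number 22 percentage points higher from compound 2 to compound 3 (beyond the scatter), still stands with the fluorine present. Nothing measured here accounts for either step.

Going by these compounds, it stays open whether a larger group on this same carbon, such as methoxy or an amine, would move the number beyond the scatter, and whether fluoro on the other aromatic carbons of this ring would behave alike. On these data alone, the placing of the methylsulfonyl group on the ring also stays open, and compound 1 gives "not determined" (no result reported) in this assay and offers no comparison.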